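The compounds below may be only part of what the source reports. "The series", "measured", "known", "first", "only" and "open" are said of these compounds alone.

This account follows a single change made on compound 3 `O=C(O)c1c(Cn2c(=O)n(C3CC3)c3ccncc32)nc2cc(Cl)ccn12` and what it may do to how much of the compound HEp-2 cells tolerate. In an ADME assay on HEp-2 cells (Homo sapiens) for cytotoxicity, read by CCK-8 assay, with a stated time of 6 days (a lower number here means that less compound is tolerated, a higher number that more compound is tolerated), compound 3 gives > 100000 nM, which is a limit of the assay and not a number. Two neighbours share the same core. Compound 1 `Cc1ccc2nc(Cn3c(=O)n(C4CC4)c4ccncc43)c(CCCCO)n2c1` gives > 100000 nM in this assay, again a limit. Compound 2 `O=c1n(Cc2nc3ccc(F)cn3c2CCCCO)c2cnccc2n1C1CC1` gives > 100000 nM in this assay, also a limit. Going by the values given here, the only single-point step between measured compounds, a step that the two limits leave unreadable from compound 1 to compound 2, cannot be read because of the limit of > 100000 nM in this assay, at which 3 of the 3 values shown sit. Compound 4 `CS(=O)(=O)c1ccc(-c2c(Cn3c(=O)n(C4CC4)c4ccncc43)nc3cc(Cl)ccn23)cc1` arises from compound 3 by the change (4-(methylsulfonyl)phenyl in place of carboxy on an aromatic carbon). Among the compounds with values here, no measured step touches this position or these groups, so the measured compounds give no indication of direction or size. Since every measured value in this assay rests at the limit, compound 4 is expected to stay near it, and the step of a number no higher from compound 3 to compound 4 (the limit leaves the size open) is expected to be small. The estimate for compound 4 in this assay is 100000 nM, within a range from 30000 nM to 300000 nM, with a fair chance that only a limit is reported again.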

Compound 4, half-maximal cytotoxic concentration: > 100000 nM
Compound 4: no number, only a limit; the forecaster's own chance of this, stated with the estimate: 65%; the middle value lies on the limit itself.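

No size can be read for the change from compound 3 to compound 4 in this assay, because both give only a limit and not a number: the limit of > 100000 nM in this assay, at which 4 of the 4 values shown sit.

The compounds shown leave open whether 4-(methylsulfonyl)phenyl in place of carboxy alters how much compound HEp-2 cells tolerate.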